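Chloro to bromo on the aryl group of compound 3

The source may hold more compounds than are shown below. What is called first, only, known or untested is meant among the compounds shown, and "the series" means these compounds.

Three compounds share one core and have been run in a functional assay on the whole organism (strain Wistar) for inhibition, with Rattus norvegicus as the target, read by paw edema, with a stated time of 4 h, at a dose of 10 mg/kg by the oral route; on this read-out higher numbers stand for more inhibition at the one dose given (going by the name of the read-out) and lower numbers for less inhibition. Compound 1 `Clc1ccc(-c2nnc(COc3ccc(-c4ccccc4)cc3)o2)cc1` gives 77.3% in this assay. Compound 2 `CCCCn1c(S)nnc1COc1ccc(-c2ccccc2)cc1` gives 81.8% in this assay. Compound 3 `Sc1nnc(COc2ccc(-c3ccccc3)cc2)n1-c1ccc(Cl)cc1` gives 18.2% in this assay, the lowest of the three numbers, and both other compounds lie beyond the scatter above it. Within the data shown here, the only single-change step measured so far is a number 63.6 percentage points lower from compound 2 to compound 3 (beyond the scatter), so the group on the aromatic nitrogen of the shared core clearly moves the read-out.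

Compound 4 `Sc1nnc(COc2ccc(-c3ccccc3)cc2)n1-c1ccc(Br)cc1` differs from compound 3 by bromo in place of chloro on an aromatic carbon; cut one bond further out, the change reads 4-chlorophenyl to 4-bromophenyl. Among the measured compounds shown here, no measured step exchanges one halogen for another, so the step from compound 2 to compound 3 is the only one touching this part of the molecule, and it bears on the present change only in showing that the group on the aromatic nitrogen matters. With nothing else to go on, the change from compound 3 to compound 4 is expected to give a step of a number 1.8 percentage points higher from compound 3 to compound 4 (within the scatter), which stays within the scatter. Compound 4 is therefore estimated at 20% in this assay, with a range from 6% to 38%.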

Compound 4, a percentage reported as inhibition, in the whole organism at one dose (the size of the read-out at that dose, not a potency): 31.8%
For compound 4 the middle estimate is 11.8 percentage points below the measured one; the measured number falls inside the stated range.
By their numbers in this assay, from the lowest: compound 3; then compound 4; then compounds 1 and 2 (each within the scatter of the next).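

Working in this assay, the halogen on the aryl group is the first change shown to move the read-out while the nitrogen substituent remains an aryl group: bromo in place of chloro gives a number 13.6 percentage points higher from compound 3 to compound 4 (beyond the scatter) as a modest step. The group on the aromatic nitrogen still has the larger effect, since 4-bromophenyl in place of butyl gives a number 50 percentage points lower from compound 2 to compound 4 (beyond the scatter) and 4-chlorophenyl in place of butyl gives a number 63.6 percentage points lower from compound 2 to compound 3 (beyond the scatter) in the earlier comparison, so the exchange of halogen closes only part of the gap to compound 2. No supporting measurement bears on the difference between chloro and bromo here.

As far as these compounds go, whether the trend extends to other groups on this aromatic carbon, such as fluoro, methoxy or an amine, remains open, as does whether a longer chain than butyl on the aromatic nitrogen keeps the read-out near that of compound 2. From the compounds shown here alone, it also remains open whether bromo in place of chloro on compound 1 would move the read-out as it does between the two aryl compounds.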